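Fluorophenyl amide in a bromo-nitrophenyl triazene series

The source may report more compounds than this note shows. Statements on the series, on what has been measured and on what is new or still open speak of the compounds shown alone.

Measured so far:
compound 1 `O=C(c1ccccc1C(F)(F)F)N(/N=N/c1ccc([N+](=O)[O-])cc1Br)c1ccc([N+](=O)[O-])cc1Br`: 13300 nM
compound 2 `O=C(c1cccc(C(F)(F)F)c1)N(/N=N/c1ccc([N+](=O)[O-])cc1Br)c1ccc([N+](=O)[O-])cc1Br`: 1120 nM

In a functional assay on HeLa cells (Homo sapiens) for cytotoxicity, read by MTT assay, with a stated time of 72 h (a lower number here means a stronger inhibitor, a higher number a weaker inhibitor), compound 2 gives 1120 nM, the lower of the two numbers, and compound 1 gives 13300 nM. Among the measured compounds shown here, the one measured step, a 12-fold lower number from compound 1 to compound 2 (1.07 log units; beyond the scatter), shows that the aryl group on the carbonyl carbon matters a great deal. Compound 3 `O=C(c1ccc(F)cc1)N(/N=N/c1ccc([N+](=O)[O-])cc1Br)c1ccc([N+](=O)[O-])cc1Br` differs from compound 2 by 4-fluorophenyl in place of 3-(trifluoromethyl)phenyl on a carbonyl carbon. For the measured compounds named here, no measured step swaps trifluoromethyl for fluorine, so the direction is uncertain; the size of the step from compound 1 to compound 2 suggests the change could be large. The expected step is a 2.2-fold higher number from compound 2 to compound 3 (0.35 log units; beyond the scatter), so compound 3 is estimated at 2500 nM, within 600 nM to 10000 nM.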

Compound 3, half-maximal inhibitory concentration: 580 nM
Estimate against measurement, compound 3: 4.3-fold (0.63 log units) above; the whole stated range lies above it.
By their numbers in this assay, from the lowest: compounds 3 and 2 (each within the scatter of the next); then compound 1.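

In this assay, a 1.9-fold lower number from compound 2 to compound 3 (0.29 log units; within the scatter) lies within the usual scatter, so 4-fluorophenyl and 3-(trifluoromethyl)phenyl cannot be told apart on this carbonyl carbon. The a 23-fold lower number from compound 1 to compound 3 (1.36 log units; beyond the scatter) lies beyond the scatter, so of the three groups shown, only 2-(trifluoromethyl)phenyl stands apart, with the higher number. Nothing available explains this difference. The compounds shown leave open how a phenyl ring carrying an amine or a carboxylic acid would behave here. They also leave open what a longer chain in place of the ring would do.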